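Swapping the aryl group on the triazole-bound methylene

The source may report more compounds than this note shows. Statements on the series, on what has been measured and on what is new or still open speak of the compounds shown alone.

Compound 2 `S=C(SCc1cn(Cc2ccccc2Cl)nn1)N1CCNCC1` was tested in a functional assay on MCF7 cells (Homo sapiens) for inhibition, read by MTT assay, with a stated time of 72 h (a lower number here means a stronger inhibitor, a higher number a weaker inhibitor), and gives 38900 nM. Its neighbours are compound 1 `Fc1ccccc1Cn1cc(CSC(=S)N2CCNCC2)nn1` with 33200 nM and compound 3 `O=C(OCc1ccccc1)N1CCN(C(=S)SCc2cn(Cc3ccccc3Cl)nn2)CC1` with 21400 nM; the shifts a 1.2-fold higher number from compound 1 to compound 2 (0.07 log units; within the scatter) and a 1.8-fold lower number from compound 2 to compound 3 (0.26 log units; within the scatter) are both within the scatter, so the three compounds cannot be told apart. Compound 4 `Cc1ccc(Cn2cc(CSC(=S)N3CCNCC3)nn2)cc1` is not yet measured; it differs from compound 2 by 4-methylphenyl in place of 2-chlorophenyl on a saturated chain carbon bound to an aromatic nitrogen. Among the compounds with values here, of the measured steps only the one from compound 1 to compound 2 touches the same aryl group, and it was within the scatter. No step beyond the scatter has been seen, so compound 4 is expected to show a shift a 1.1-fold lower number from compound 2 to compound 4 (0.05 log units; within the scatter) of no real size, with an estimate of 35000 nM and a range from 15000 nM to 80000 nM.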

Compound 4, half-maximal inhibitory concentration: 53200 nM
Beside the measured number, compound 4's estimate is 1.5-fold (0.18 log units) below it, within the range that was stated.
By their numbers in this assay, from the lowest: compounds 3, 1, 2 and 4 (each within the scatter of the next, the first and the last beyond it).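

In this assay the swap to 4-methylphenyl gives a 1.4-fold higher number from compound 2 to compound 4 (0.14 log units; within the scatter) and a 1.6-fold higher number from compound 1 to compound 4 (0.20 log units; within the scatter) and so the methyl-carrying ring cannot be told apart from the two halogen-carrying rings. The aryl group at this place has now been varied beyond one halogen for another, still with no step beyond the scatter. Nothing measured here bears on these numbers. As far as these compounds go, whether a phenyl group carrying an amine or a carboxylic acid would give a step beyond the scatter stays open. So does the outcome of a longer chain in place of the aryl group.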